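Replacing Bromo with 2-Carboxyethenyl on a Benzyl Arm

The source may report more compounds than this note shows. Statements on the series, on what has been measured and on what is new or still open speak of the compounds shown alone.

Compound 3 `COC(=O)/C=C/c1cccc(N(Cc2ccc(Br)cc2)C(=O)C2CCCCC2)c1` sits at the edge of what an assay on isolated protein with Bile acid receptor (Homo sapiens) as the target (on this read-out lower numbers stand for an effect already at smaller amounts and higher numbers for an effect only at larger amounts of compound), can report: in this assay compound 3 gives > 1000 nM, which is a limit of the assay rather than a number. Two measured neighbours frame it. Compound 1 `COC(=O)/C=C/c1cccc(N(Cc2ccc(-c3c(OC)cccc3OC)cc2)C(=O)C2CCCCC2)c1` carries a 2,6-dimethoxyphenyl group where compound 3 carries bromo, and in this assay compound 1 gives 77 nM. Compound 2 `COC(=O)/C=C/c1cccc(N(C)C(=O)C2CCCCC2)c1` has hydrogen in place of the whole 4-bromophenyl; in this assay compound 2 gives > 1000 nM, again a limit. The step of an at least 12-fold higher number from compound 1 to compound 3 (1.11 log units; beyond the scatter) shows that a large group at that position can matter greatly, while the step that the two limits leave unreadable from compound 2 to compound 3 cannot be sized, since both ends rest at the limit of > 1000 nM in this assay, at which 2 of the 3 values shown sit.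

Compound 4 `COC(=O)/C=C/c1cccc(N(Cc2ccc(/C=C/C(=O)O)cc2)C(=O)C2CCCCC2)c1` now replaces the bromo of compound 3 with a longer substituent: 2-carboxyethenyl in place of bromo on an aromatic carbon. Among the measured compounds shown here, the only informative comparison is compound 1, whose 77 nM shows that a 2,6-dimethoxyphenyl group on that aromatic carbon is compatible with a measurable value. The expected step for compound 4 is an at least 1.6-fold lower number from compound 3 to compound 4 (0.22 log units; that floor lies within the scatter). The estimate for compound 4 is 600 nM, between 150 nM and 3000 nM.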

Compound 4, half-maximal effective concentration: > 1000 nM
Compound 4 ended at the assay's limit; the forecaster's own chance of this, stated with the estimate: 45%; at least 1.6-fold (0.22 log units) between middle value and limit.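

Compound 4 shows that a carboxylic acid-bearing chain on this aromatic carbon, like bromo in compound 3, does not bring the compound to a readable value in this assay; its result is a limit of the assay, not a number. The change from 2,6-dimethoxyphenyl to 2-carboxyethenyl at this position gives an at least 12-fold higher number from compound 1 to compound 4 (1.11 log units; beyond the scatter), so among the groups shown here, only the 2,6-dimethoxyphenyl of compound 1 gives a measurable value. The steps to compound 4 from compound 3 and from compound 2 cannot be read, because both ends of each step rest at the same limit: the limit of > 1000 nM in this assay, at which 3 of the 4 values shown sit.

As far as these compounds go, how far compound 4, compound 3 and compound 2 lie beyond that limit remains unknown, so these three cannot be ranked against one another. From the compounds shown here alone, it also remains open whether a plain phenyl, a 2-methoxyphenyl or a 2-(methoxycarbonyl)ethenyl group on this aromatic carbon would give a measurable value, and so which part of the 2,6-dimethoxyphenyl group matters in compound 1.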